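This account rests on a few compounds, and the source may have more. Where it says the series, first, only, none or still open, it means among the compounds named here.

Measured compounds:

Compound 1 `CCCn1c(=O)n(C)c(=O)c2[nH]c(-c3ccccc3)nc21` with 6.3 nM
Compound 2 `CCCn1c(=O)c2nc(-c3ccc(O)cc3)[nH]c2n(C)c1=O` with 1.28 nM
Compound 3 `CCCn1c(=O)c2nc(-c3ccc(C#N)cc3)[nH]c2n(CCC)c1=O` with 4.48 nM

Of the compounds shown here, three sharing one core have been tested in an assay on Cortex for displacement of a labelled ligand from adenosine receptor A1 (Rattus norvegicus); on this read-out higher numbers stand for weaker inhibition and lower numbers for stronger inhibition. Compound 1 gives 6.3 nM, the highest of the three numbers. Compound 3, at 4.48 nM, sits within the scatter of compound 1, so no order between these two can be read. Compound 2, at 1.28 nM, lies clearly below compound 1, beyond the scatter; no single-place step connects these two compounds, so only the two values themselves are shown here.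

Compound 4 `CCCn1c(=O)n(C)c(=O)c2[nH]c(C3CCCCC3)nc21` has not yet been measured. It differs from compound 1 by a single change: cyclohexyl in place of phenyl on an aromatic carbon. Within the data shown here, no measured pair in this set reports such a swap of an aromatic ring for a saturated ring, so any expectation for compound 4 rests on the structural change alone and on the values of the three measured compounds. A step of modest size is expected, toward a lower number in this assay, though the outcome could also stay within the scatter of compound 1. The estimated step from compound 1 to compound 4 is a 2.1-fold lower number from compound 1 to compound 4 (0.32 log units; beyond the scatter). Compound 4 is expected to give about 3 nM in this assay, with a range from 0.8 nM to 12 nM.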

Compound 4, inhibition constant: 1.81 nM
Beside the measured number, compound 4's estimate is 1.7-fold (0.22 log units) above it; measured number inside the range.
By their numbers in this assay, from the lowest: compounds 2 and 4 (each within the scatter of the next); then compounds 3 and 1 (each within the scatter of the next).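

In this assay, among these compounds, the swap of phenyl for cyclohexyl on an aromatic carbon gives a 3.5-fold lower number from compound 1 to compound 4 (0.54 log units; beyond the scatter) and is the first step in this set that links two compounds differing in one place. It shows that this place, on the five-membered aromatic ring with 2 nitrogen, does not require an aromatic ring for a low number: one six-membered non-aromatic ring of carbon only, with the same count of heavy atoms as phenyl and likewise no hydrogen-bond donors or acceptors, is tolerated, and the number falls beyond the scatter. No measurement available here accounts for the size or direction of this step.

The compounds shown leave open how far the ring itself matters at this place, since a smaller saturated ring such as cyclopentyl, an open chain such as butyl, or a ring carrying an amine, such as piperidine, has no value here. As far as these compounds go, it also remains open whether the same swap would give a step of similar size on a core with the two propyl chains of compound 3, or on a cyclohexyl ring bearing a hydroxyl group.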